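The source may report more compounds than this note shows. Statements on the series, on what has been measured and on what is new or still open speak of the compounds shown alone.

Measured compounds:
Compound 1, `COc1ccc(/C=C/C(=O)c2ccccc2-c2ccc(F)nc2)cc1`: 930 nM
Compound 2, `COc1ccc(/C=C/C(=O)c2ccccc2-c2ccc(F)nc2)cc1OC`: 1200 nM
Compound 3, `COc1ccc(C(=O)/C=C/c2ccccc2-c2ccc(F)cc2)cc1`: 8200 nM

All three were tested in a functional assay on A549 cells (Homo sapiens) for antiproliferative activity, read by sulforhodamine B assay, with a stated time of 48 h; on this read-out higher numbers stand for weaker inhibition and lower numbers for stronger inhibition. Compound 2 is obtained from compound 1 by a single change, (methoxy in place of hydrogen on an aromatic carbon), and this change made a step of a 1.3-fold higher number from compound 1 to compound 2 (0.11 log units; within the scatter), so the two values are not told apart by this assay. Compound 3 is built on a different core; the difference between the two cores is not broken down here. In this assay compound 3 gives the highest number of the three, and the gap to compound 1 and to compound 2 is larger than the scatter.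

Compound 4, `COc1ccc(C(=O)/C=C/c2ccccc2-c2ccc(F)cc2)cc1OC`, is not yet measured. Among the compounds with values here, it comes from compound 3 by methoxy in place of hydrogen on an aromatic carbon, which is the same change, at the same place, as the one from compound 1 to compound 2. The step from compound 3 to compound 4 is expected to be a 1.2-fold higher number from compound 3 to compound 4 (0.06 log units; within the scatter), because the same change gave only a 1.3-fold higher number from compound 1 to compound 2 (0.11 log units; within the scatter) on the other core, with the caution that this rests on a single earlier example. Compound 4 is therefore expected to give about 9500 nM, estimated to lie between 4000 nM and 22000 nM.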

Compound 4, half-maximal inhibitory concentration: 7500 nM
The estimate for compound 4 lay 1.3-fold (0.10 log units) above the measured number; low and high end bracket the measured number.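

In this assay, putting methoxy in place of hydrogen gave a 1.1-fold lower number from compound 3 to compound 4 (0.04 log units; within the scatter), so compound 3 and compound 4 are not told apart. Set beside the earlier pair, the change gives the same picture on both cores, with neither step large enough to count as a real shift and no real difference between the two steps: the same change on two cores in this assay, a 1.3-fold higher number (0.11 log units; within the scatter) from compound 1 to compound 2 and a 1.1-fold lower number (0.04 log units; within the scatter) from compound 3 to compound 4, 1.4-fold (0.15 log units) apart, within the scatter of two such steps. Within the data shown here, this suggests that, for these two pairs, the methoxy group can be carried from one core to the other without a visible change in the result, but it rests on only two examples and says nothing about a third core, another place on the ring, or why the step is so small.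

The compounds shown leave open what a different group at this place would do, such as a hydroxyl, an amine or a longer chain like ethoxy. They also leave open which part of the difference between the two cores goes with the gap in values between them.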